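Methylamino in place of morpholine: what compound 4 may give

The compounds below may be only part of what the source reports. "The series", "measured", "known", "first", "only" and "open" are said of these compounds alone.

Measured compounds and their numbers in an assay on a protein complex for inhibition of CDK8/Cyclin C (Homo sapiens), with a stated time of 1 h; a higher number here means a weaker inhibitor, a lower number a stronger inhibitor:
compound 1 `NC(=O)/C=C/c1ccncc1-c1ccc2ccccc2c1` gives 10.5 nM
compound 2 `O=C(/C=C/c1ccncc1-c1ccc2ccccc2c1)NC1CC1` gives 40.1 nM
compound 3 `O=C(/C=C/c1ccncc1-c1ccc2cc[nH]c2c1)N1CCOCC1` gives 43.9 nM

Compound 3 has the highest of the three numbers in this assay. Its nearest neighbour is compound 2, whose number lies within the scatter of that of compound 3; the furthest is compound 1, whose lower number lies beyond the scatter. Compound 4 `CNC(=O)/C=C/c1ccncc1-c1ccc2cc[nH]c2c1` is compound 3 with a single change: methylamino in place of morpholin-4-yl on a carbonyl carbon.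

For the measured compounds named here, the only measured step at the amide-type nitrogen is a 3.8-fold higher number from compound 1 to compound 2 (0.58 log units; beyond the scatter), a modest move to a weaker inhibitor. It runs on a different core from that of compound 3 and swaps hydrogen for cyclopropyl rather than a ring-bearing nitrogen for methylamino, so it bears on the present step only loosely. Going by the values given here, compound 4 does carry one hydrogen-bond donor, as compounds 1 and 2 do and compound 3 does not, but no measured pair isolates that feature. The expectation in this assay is therefore a small step, if any, toward a lower number, close to the scatter. For compound 4 the estimate is 25 nM, with a range from 10 nM to 65 nM. The step this estimate implies is expected to be a 1.8-fold lower number from compound 3 to compound 4 (0.24 log units; within the scatter).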

Compound 4, half-maximal inhibitory concentration: 18.6 nM
Compound 4: middle estimate off by 1.3-fold (0.13 log units), on the high side; the measured number falls inside the stated range.
By their numbers in this assay, from the lowest: compounds 1 and 4 (each within the scatter of the next); then compounds 2 and 3 (each within the scatter of the next).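

On the core shared by compound 3 and compound 4, this assay records a 2.4-fold lower number from compound 3 to compound 4 (0.37 log units; beyond the scatter) when methylamino replaces morpholin-4-yl on a carbonyl carbon, which shows that the number on this core responds to the group at this carbonyl. The earlier step of a 3.8-fold higher number from compound 1 to compound 2 (0.58 log units; beyond the scatter) ran toward a weaker inhibitor on a different core, so the two steps together show that changes around this carbonyl can move the number either way, although they differ in both core and group and form no single trend. No measured information accounts for the step on this core.

With morpholin-4-yl leaving and methylamino entering, a ring, a hydrogen-bond acceptor and a hydrogen-bond donor all change at once, and the compounds shown do not separate these features; dimethylamino or piperidin-1-yl on the same carbonyl would bear on that question. The compounds also leave open how the unsubstituted amino group or cyclopropylamino would read on the core of compound 4, which would show whether the step seen on the core of compound 1 carries over.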